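The source may report more compounds than this note shows. Statements on the series, on what has been measured and on what is new or still open speak of the compounds shown alone.

Going by the values given here, the two compounds measured so far share one core. Compound 1 `OCCCNCc1nc2c(OCC3CCCCC3)cccc2[nH]1` gives 52.7% in an assay on cells for inhibition of interleukin-5 receptor subunit alpha (Mus musculus), read by WST assay, with a stated time of 48 h, tested at 30 uM, in the presence of a further agent that is not named here; on this read-out lower numbers stand for less inhibition and higher numbers for more inhibition at the one concentration tested (going by the name of the read-out). Compound 2 `OCC(NCc1nc2c(OCC3CCCCC3)cccc2[nH]1)c1ccccc1`, with 2-hydroxy-1-phenylethyl in place of 3-hydroxypropyl on the amine nitrogen, gives 77.7% in this assay. That single change brought a number 25 percentage points higher from compound 1 to compound 2 (beyond the scatter). Among the compounds with values here, on the numbers so far compound 2 stands highest of the two, and its only neighbour, compound 1, lies a number beyond the scatter below it.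

Compound 3 `OCCC(NCc1nc2c(OCC3CCCCC3)cccc2[nH]1)c1ccccc1` has not yet been measured. It differs from compound 2 in one place: hydroxymethyl in place of hydroxy on a saturated chain carbon, two bonds along the chain from an amine nitrogen and an aromatic carbon. Within the data shown here, the only measured step, a number 25 percentage points higher from compound 1 to compound 2 (beyond the scatter), exchanged the whole group on the amine nitrogen at once, chain and phenyl together, so it gives no direct reading on lengthening a chain by one carbon while the phenyl stays. Among the measured compounds shown here, no measured step tests a change of this kind, so the step of a number 2.7 percentage points lower from compound 2 to compound 3 (within the scatter) is expected to stay within the scatter. Compound 3 is therefore estimated at 75% in this assay, with a range from 55% to 90%.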

Compound 3, a percentage reported as inhibition, at one concentration (the size of the read-out at that concentration, not a potency): 64.7%
Compound 3: middle estimate off by 10.3 percentage points, on the high side, and the stated range covers the measured number.
By their numbers in this assay, from the lowest: compound 1; then compound 3; then compound 2.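

With the phenyl kept in place, going from hydroxymethyl to 2-hydroxyethyl on a saturated chain carbon, two bonds along the chain from an amine nitrogen and an aromatic carbon, gives a number 13 percentage points lower from compound 2 to compound 3 (beyond the scatter) in this assay, so one extra carbon in this arm is enough to move the read-out. Compound 3 also separates the phenyl from the chain length, which the first exchange changed together: with the 3-hydroxypropyl chain kept, phenyl in place of hydrogen on a saturated chain carbon bound to an amine nitrogen and a saturated chain carbon gives a number 12 percentage points higher from compound 1 to compound 3 (beyond the scatter). The data offer no measured explanation for either step.

These three compounds leave open whether a still longer chain, such as 3-hydroxypropyl, would lower the number further or whether the shorter hydroxy arm of compound 2 marks a real preference. They also leave open whether the terminal hydroxy could be exchanged for an amine or a carboxylic acid, and how these percentages at a single concentration would translate into potency.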